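The source may report more compounds than this note shows. Statements on the series, on what has been measured and on what is new or still open speak of the compounds shown alone.

Measured so far:
compound 1, `COc1cc(Cl)cc(-c2nn(-c3cccc(NC(=O)Nc4ccc(Cl)c(C(F)(F)F)c4)c3)cc2-c2ccncc2)c1`, -30.8%
compound 2, `COc1cc(Cl)cc(-c2nn(-c3cccc(NC(=O)Nc4cc(C(F)(F)F)cc(C(F)(F)F)c4)c3)cc2-c2ccncc2)c1`, -75%

Compound 1 `COc1cc(Cl)cc(-c2nn(-c3cccc(NC(=O)Nc4ccc(Cl)c(C(F)(F)F)c4)c3)cc2-c2ccncc2)c1` and compound 2 `COc1cc(Cl)cc(-c2nn(-c3cccc(NC(=O)Nc4cc(C(F)(F)F)cc(C(F)(F)F)c4)c3)cc2-c2ccncc2)c1` share one core and differ only in the aryl attached to the urea. In a functional assay on MDA-MB-231 cells (Homo sapiens) for inhibition, read by sulforhodamine B assay, with a stated time of 48 h, tested at 10 uM (on this read-out higher numbers stand for a weaker effect at the one concentration tested and lower numbers for a stronger effect), compound 1 gives -30.8%, while compound 2 gives -75%. Compound 2 therefore stands at the lowest of the two numbers, and its nearest neighbour, compound 1, lies higher by a gap that is beyond the scatter. Compound 3 `COc1cc(Cl)cc(-c2nn(-c3cccc(NC(=O)Nc4cccc(C(F)(F)F)c4)c3)cc2-c2ccncc2)c1` has not yet been tested in this assay. It differs from compound 2 by hydrogen in place of trifluoromethyl on an aromatic carbon. Among the compounds with values here, no single-change step between measured compounds is available, so the size of this step rests on expectation alone. A step upward, toward a weaker effect and beyond the scatter, is expected, and the estimated step from compound 2 to compound 3 in this assay is a number 40 percentage points higher from compound 2 to compound 3 (beyond the scatter). Compound 3 is estimated at -35%, with a range from -75% to 5%.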

Compound 3, a percentage reported as activity, at one concentration (the size of the read-out at that concentration, not a potency): -9.21%
Estimate against measurement, compound 3: 25.8 percentage points below; measured number inside the range.
By their numbers in this assay, from the lowest: compound 2; then compound 1; then compound 3.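

The second substituent on the urea aryl ring carries much of the effect: in this assay, hydrogen in place of trifluoromethyl on an aromatic carbon gives a number 65.8 percentage points higher from compound 2 to compound 3 (beyond the scatter). Hydrogen in place of chloro on an aromatic carbon also moves the number upward, with a number 21.6 percentage points higher from compound 1 to compound 3 (beyond the scatter), so compound 3, which carries trifluoromethyl alone on that ring, is the weakest of the three, and both replacements by hydrogen weaken the effect beyond the scatter. Nothing available accounts for why either step takes the size it does.

From the compounds shown here alone, it remains open whether a group of another kind on this carbon, such as a nitrile or an amine, would keep the effect seen with compound 2. These readings at one concentration also leave open how the compounds compare in potency.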